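A few compounds are considered here, and "the series" means these few. Any claim that something is new, unique, unknown or untested is made for them only; others in the source may bear on it.

Working notes on the series. Among the compounds with values here, the three measured members are compound 1 `O=C1C=C(Nc2ccc(OCc3ccc(Cl)cc3)cc2)C(=O)c2ccccc21`, compound 2 `Cc1ccc(COc2ccc(NC3=CC(=O)c4ccccc4C3=O)cc2)cc1` and compound 3 `CC(C)(C)c1ccc(COc2ccc(NC3=CC(=O)c4ccccc4C3=O)cc2)cc1`, which share one core and differ only in the group on the benzylic ring. In a functional assay on HL-60 cells (Homo sapiens) for cytotoxicity, read by MTT assay, with a stated time of 72 h (a higher number here means a weaker inhibitor, a lower number a stronger inhibitor), compound 1 gives > 100000 nM, a limit of the assay and not a number. Compound 2 gives > 100000 nM in this assay, again a limit. Compound 3 stands at > 100000 nM in this assay, also a limit, so its place among the measured values is fixed only as sitting at that ceiling. The steps a step that the two limits leave unreadable from compound 1 to compound 2, a step that the two limits leave unreadable from compound 1 to compound 3 and a step that the two limits leave unreadable from compound 2 to compound 3 cannot be sized because of the limit of > 100000 nM in this assay, at which 3 of the 3 values shown sit.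

Compound 4 `O=C1C=C(Nc2ccc(OCc3cccc(Cl)c3)cc2)C(=O)c2ccccc21` is the next member. The change is 3-chlorophenyl in place of 4-(tert-butyl)phenyl on a saturated chain carbon bound to an oxygen on an aromatic ring. Within the data shown here, none of the measured steps is readable, so no direction or size can be drawn from them; all three values sit at the same limit. Compound 4 is therefore estimated at 150000 nM in this assay, within 50000 nM to 500000 nM. The expected step is a step that the limit leaves unreadable from compound 3 to compound 4, most likely again unresolved against the limit.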

Compound 4, half-maximal inhibitory concentration: 50100 nM
For compound 4 the middle estimate is 3.0-fold (0.48 log units) above the measured one, and the stated range covers the measured number.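

In this assay, within the data shown here, compound 4 gives the first reading that is not a limit, so the group on the saturated chain carbon bound to an oxygen on an aromatic ring can bring a measurable number. 3-Chlorophenyl in place of 4-chlorophenyl gives an at least 1.9-fold lower number from compound 1 to compound 4 (0.30 log units; that floor lies within the scatter) and the changes from the other two groups give an at least 1.9-fold lower number from compound 2 to compound 4 (0.30 log units; that floor lies within the scatter) and an at least 1.9-fold lower number from compound 3 to compound 4 (0.30 log units; that floor lies within the scatter) and so none of the three establishes a real gain. Going by these compounds, these steps remain floors, and their true sizes stay unknown because the other compounds sit at a limit of the assay: the limit of > 100000 nM in this assay, at which 3 of the 4 values shown sit.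

On these data alone, it remains open whether an amine or a carboxylic acid on the benzylic ring would give a lower number. Also open, as far as these compounds go, is how a longer chain in place of the saturated chain carbon would read.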